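From aziridine to benzylamine: what to expect of compound 4

This account rests on a few compounds, and the source may have more. Where it says the series, first, only, none or still open, it means among the compounds named here.

Compound 1 `C=CCNC1=CC(=O)c2nc(-c3ccccc3)ccc2C1=O` gives 14100 nM in a functional assay on NCI60 cells (Homo sapiens) for cytotoxicity; a higher number here means a weaker inhibitor of growth, a lower number a stronger inhibitor of growth.
Compound 2 `COCCCNC1=CC(=O)c2nc(-c3ccccc3)ccc2C1=O` gives 19100 nM in this assay.
Compound 3 `O=C1C(N2CC2)=CC(=O)c2nc(-c3ccccc3)ccc21` gives 324 nM in this assay.

Compound 3 stands lowest of the three and is therefore the strongest inhibitor of growth in this set: a 44-fold lower number from compound 1 to compound 3 (1.64 log units; beyond the scatter) and a 59-fold lower number from compound 2 to compound 3 (1.77 log units; beyond the scatter) are both large, whereas a 1.4-fold higher number from compound 1 to compound 2 (0.13 log units; within the scatter) stays within the scatter. Compound 4 `O=C1C(NCc2ccccc2)=CC(=O)c2nc(-c3ccccc3)ccc21` takes the next step: benzylamino in place of aziridin-1-yl on a double-bonded ring carbon. The two large measured steps bear directly on this. The aziridine of compound 3 separates it from two open-chain amines, each carrying a hydrogen on nitrogen, that sit far higher. The benzylamino group entering brings back a hydrogen-bond donor of the same kind, so the expectation is a large rise in this assay, roughly undoing the gain seen on going to compound 3. Compound 4 is therefore expected to give about 12000 nM, with a likely range from 3000 nM to 40000 nM, which means a 37-fold higher number from compound 3 to compound 4 (1.57 log units; beyond the scatter).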

Compound 4, concentration for total growth inhibition: 15500 nM
Estimate against measurement, compound 4: 1.3-fold (0.11 log units) below; the range from low to high includes it.
By their numbers in this assay, from the lowest: compound 3; then compounds 1, 4 and 2 (each within the scatter of the next).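

In this assay, the benzylamino group of compound 4 joins the two other amines that keep a hydrogen on nitrogen: a 1.2-fold lower number from compound 2 to compound 4 (0.09 log units; within the scatter) and a 1.1-fold higher number from compound 1 to compound 4 (0.04 log units; within the scatter) both stay within the scatter, while a 48-fold higher number from compound 3 to compound 4 (1.68 log units; beyond the scatter) is large. On this double-bonded ring carbon, then, vinyl, 2-methoxyethyl and phenyl on the chain carbon bound to the amine nitrogen give numbers that cannot be told apart, and only the aziridin-1-yl of compound 3 stands apart among these four compounds. No measurement at hand explains the gap between compound 3 and the other three.

Still open, on these data alone, is whether the three-membered ring or the missing hydrogen on nitrogen matters, which a dimethylamino group or a pyrrolidine ring on that carbon could help separate. As far as these compounds go, what a carboxylic acid on the chain would do also remains open.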